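The source may report more compounds than this note shows. Statements on the series, on what has been measured and on what is new or still open speak of the compounds shown alone.

Measured compounds:
compound 1, `Cc1nn(C)c2c(O)nc(-c3cccnc3)nc12`, 3090 nM
compound 2, `Cn1c(=O)c2nc(-c3ccc(Cl)cc3)[nH]c2n(C)c1=O`, 0.8 nM
compound 3, `Cc1nn(C)c2c(O)nc(-c3cccc([N+](=O)[O-])c3)nc12`, 1200 nM

In an assay on membranes from brain for binding affinity to adenosine receptor A1 (Rattus norvegicus), read by radioligand binding (a higher number here means a weaker inhibitor, a lower number a stronger inhibitor), compound 3 gives 1200 nM, the second highest of the three numbers. Its nearest neighbour is compound 1, whose value of 3090 nM lies higher by a margin beyond the usual scatter. Compound 2, built on a different core, stands far apart with 0.8 nM.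

Compound 4, `COc1cccc(-c2nc(O)c3c(n2)c(C)nn3C)c1`, has not yet been measured. It differs from compound 3 in one place: methoxy in place of nitro on an aromatic carbon. The substituent sits on an aromatic carbon of a six-membered aromatic ring of carbon only, meta to a large group. For the measured compounds named here, no measured pair shows this exchange, so the size of the step is uncertain. Given that compound 3 and compound 1, which also differ only in the aromatic ring attached to the shared core, stay close to each other, the change in this assay from compound 3 to compound 4 is expected to be modest, a 1.7-fold higher number from compound 3 to compound 4 (0.22 log units; within the scatter), leaning towards a somewhat higher number. Compound 4 is therefore estimated at 2000 nM, in a range from 600 nM to 6500 nM.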

Compound 4, half-maximal inhibitory concentration: 1470 nM
Compound 4: the middle estimate sits 1.4-fold (0.13 log units) above what was measured, within the range that was stated.
By their numbers in this assay, from the lowest: compound 2; then compounds 3 and 4 (each within the scatter of the next); then compound 1.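

In this assay, putting methoxy in place of nitro on an aromatic carbon, meta to a large group, gives a 1.2-fold higher number from compound 3 to compound 4 (0.09 log units; within the scatter) and so leaves the number where it was. For the compounds shown here, this is the first pair that differs in one place only, and it shows that at this position the exchange of one group for the other, with a different set of atoms and a different count of hydrogen-bond acceptors, does not move the value beyond the scatter. Nothing available accounts for this result. What the compounds shown leave open is whether an amine, a carboxylic acid or a longer chain such as butoxy at this position would leave the number equally unmoved. They also leave open whether methoxy and nitro would stay as close on another carbon of the same ring.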